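The compounds below may be only part of what the source reports. "The series", "measured", "known", "first", "only" and "open" are said of these compounds alone.

Compound 1, `Cc1cc(C#N)cc(C)c1Oc1ccnc(Nc2ccc(C#N)cc2)n1`, was examined in a physicochemical assay for lipophilicity (a higher number here means a more lipophilic compound, a lower number a more polar compound), where compound 1 gives 1.39. Compound 2, `Cc1cc(C#N)cc(C)c1Nc1ccnc(Nc2ccc(C#N)cc2)n1`, shares much of this arrangement, but the difference between the two cores is not broken down here; in this assay compound 2 gives 1.21, and the two numbers lie within the usual scatter of each other. Compound 3, `Cc1cc(C#N)cc(C)c1Nc1nc(Nc2ccc(C#N)cc2)ncc1Cl`, carries one further group on the core of compound 2, (chloro in place of hydrogen on an aromatic carbon), and in this assay compound 3 gives 1.11. The step is a number 0.10 log units lower from compound 2 to compound 3 (within the scatter), so small that it sits within the scatter.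

Compound 4, `Cc1cc(C#N)cc(C)c1Oc1nc(Nc2ccc(C#N)cc2)ncc1Cl`, has not yet been measured. It stands to compound 1 as compound 3 stands to compound 2: the change is chloro in place of hydrogen on an aromatic carbon, the same change at the same place. Because the measured pair gave a number 0.10 log units lower from compound 2 to compound 3 (within the scatter), the expected step for compound 4 is a number 0.10 log units lower from compound 1 to compound 4 (within the scatter), taken from the value of compound 1, 1.39. On that basis compound 4 is estimated to give 1.29 in this assay, between 1.05 and 1.55.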

Compound 4, partition coefficient: 1.29
Estimate against measurement, compound 4: no gap at the digits printed, and the stated range covers the measured number.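

In this assay chloro in place of hydrogen on an aromatic carbon gives a number 0.10 log units lower from compound 1 to compound 4 (within the scatter) and the same change on the core of compound 2 gives a number 0.10 log units lower from compound 2 to compound 3 (within the scatter) so the two steps have the same printed size and, in these two pairs, the step read on one core carried over to the other. Both steps lie within the scatter, however, so this agreement does not show that the chloro group shifts the number on either core, and two pairs do not establish a rule for the whole series. Nothing given here bears on why the two steps match.

The compounds shown leave open whether a bromo group, an amine or a carboxylic acid on that same aromatic carbon would give a step beyond the scatter. They also leave open whether any such step would keep its size when moved between the core of compound 1 and the core of compound 2.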